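The source may hold more compounds than are shown below. What is called first, only, known or untested is meant among the compounds shown, and "the series" means these compounds.

Compound 1 `O=C(CCCCCCc1ccccc1)c1ncc(-c2ccccc2F)o1` gives the highest number of the three measured compounds in an assay (Rattus norvegicus) for inhibition of Fatty-acid amide hydrolase 1 (Homo sapiens) (on this read-out lower numbers stand for stronger inhibition and higher numbers for weaker inhibition), at 110 nM. Replacing its 2-fluorophenyl group helped twice: compound 2 `N#Cc1cccc(-c2cnc(C(=O)CCCCCCc3ccccc3)o2)c1` gives 15 nM, a change of a 7.3-fold lower number from compound 1 to compound 2 (0.87 log units; beyond the scatter), and compound 3 `Cc1cccnc1-c1cnc(C(=O)CCCCCCc2ccccc2)o1` gives 15 nM, a change of a 7.3-fold lower number from compound 1 to compound 3 (0.87 log units; beyond the scatter); between them there was no change at the digits printed from compound 2 to compound 3 (within the scatter). Compound 4 `O=C(CCCCCCc1ccccc1)c1ncc(-c2ncccc2C(=O)O)o1` makes a related change: 3-carboxypyridin-2-yl in place of 2-fluorophenyl on an aromatic carbon. Within the data shown here, it keeps the pyridine ring of compound 3 but carries a carboxylic acid where compound 3 has a methyl, and no measured step tests that carboxyl. The expected step is therefore a lower number, as in a 7.3-fold lower number from compound 1 to compound 3 (0.87 log units; beyond the scatter), but with wider uncertainty; the estimate means a 3.1-fold lower number from compound 1 to compound 4 (0.50 log units; beyond the scatter). Compound 4 is expected to give 35 nM, between 8 nM and 150 nM.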

Compound 4, inhibition constant: > 50 nM
Compound 4 gave a limit, no number; the forecaster's own chance of this, stated with the estimate: 5%; middle value at least 1.4-fold (0.15 log units) away from the limit.
By their numbers in this assay, from the lowest: compounds 2 and 3 (each within the scatter of the next); then compound 1.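

In this assay compound 4 gave a limit, not a number: the limit of > 50 nM in this assay, at which 1 of the 4 values shown sits. Even so, the result shows that this position on the pyridine ring is not indifferent to its group, since carboxy in place of methyl gives an at least 3.3-fold higher number from compound 3 to compound 4 (0.52 log units; beyond the scatter), and the whole 3-carboxypyridin-2-yl group also falls short of 3-cyanophenyl, with an at least 3.3-fold higher number from compound 2 to compound 4 (0.52 log units; beyond the scatter). The step from the 2-fluorophenyl compound cannot be read, so the two groups cannot be ranked.

As far as these compounds go, the true size of the loss stays open. So does whether a methyl ester or an amine in the same place would match the methyl group of compound 3.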